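A few compounds are considered here, and "the series" means these few. Any claim that something is new, unique, unknown or untested is made for them only; others in the source may bear on it.

Measured compounds:
- compound 1, `COc1cc2ccnc(-c3ccc(N)cc3)c2cc1OC`: in an assay on heart for inhibition of phosphodiesterase 1 (Bos taurus), read by cAMP accumulation (a lower number here means a stronger inhibitor, a higher number a weaker inhibitor), compound 1 gives 7400 nM
- compound 2, `C=CC(=O)Nc1ccc(-c2nccc3cc(OC)c(OC)cc23)cc1`: in this assay compound 2 gives 12000 nM
- compound 3, `COc1cc2ccnc(-c3ccc(NC(=O)CCl)cc3)c2cc1OC`: in this assay compound 3 gives 5000 nM

Among these three, compound 2 has the highest number. Its nearest neighbour is compound 1, since a 1.6-fold higher number from compound 1 to compound 2 (0.21 log units; within the scatter); its furthest is compound 3, since a 2.4-fold lower number from compound 2 to compound 3 (0.38 log units; beyond the scatter). So compound 2 sits at the weak end of a narrow spread.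

Compound 4, `COC(=O)/C=C/C(=O)Nc1ccc(-c2nccc3cc(OC)c(OC)cc23)cc1`, has not yet been measured. It differs from compound 2 in one place: 2-(methoxycarbonyl)ethenyl in place of vinyl on a carbonyl carbon

One measured step speaks directly to this change, because it also alters the group on the carbonyl carbon of compound 2: a 2.4-fold lower number from compound 2 to compound 3 (0.38 log units; beyond the scatter), a modest shift. The other step, a 1.5-fold lower number from compound 1 to compound 3 (0.17 log units; within the scatter), shows that adding a group to the ring nitrogen barely moved the number. Taken together, changes at this position have so far produced small effects only, so a small step, perhaps toward a lower number, is expected here, without confidence that it clears the scatter.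

Compound 4 is therefore expected to give about 8000 nM in this assay, within a range of 3000 nM to 20000 nM. The step from compound 2 that this estimate implies is a 1.5-fold lower number from compound 2 to compound 4 (0.18 log units; within the scatter).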

Compound 4, half-maximal inhibitory concentration: 14000 nM
Beside the measured number, compound 4's estimate is 1.8-fold (0.24 log units) below it, within the range that was stated.
By their numbers in this assay, from the lowest: compounds 3, 1, 2 and 4 (each within the scatter of the next, the first and the last beyond it).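

In this assay the group on the carbonyl carbon grows from vinyl, with 2 heavy atoms, to 2-(methoxycarbonyl)ethenyl, with 6 heavy atoms, and the result is a 1.2-fold higher number from compound 2 to compound 4 (0.07 log units; within the scatter) and so compound 2 and compound 4 cannot be told apart. Building the whole (2-(methoxycarbonyl)ethenyl)carbonyl group onto the bare nitrogen likewise gives a 1.9-fold higher number from compound 1 to compound 4 (0.28 log units; within the scatter) and this also stays inside the usual scatter, so even this larger group produces no clear shift from the unsubstituted nitrogen. Within the data shown here, the only new step that clears the scatter is a 2.8-fold higher number from compound 3 to compound 4 (0.45 log units; beyond the scatter) and it is modest, which leaves the chloromethyl compound 3 apart from compound 2 and compound 4, though not from compound 1.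

No measurement at hand explains any of these steps. Still open, as far as these compounds go, is whether a carboxylic acid in place of the methoxycarbonyl group, a saturated propyl chain in place of vinyl, or an amine at the end of a longer chain would move the number well beyond the scatter, since every compound so far lies in one narrow, weak band.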